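Compound 3 to compound 4: one added methyl

The source may hold more compounds than are shown below. What is called first, only, known or untested is meant among the compounds shown, and "the series" means these compounds.

Compound 1 `CC(C)(C)c1ccc(NC2=NCCO2)cc1`: 1500 nM
Compound 2 `Ic1ccc(NC2=NCCO2)cc1`: 1300 nM
Compound 3 `Cc1ccc(NC2=NCCO2)cc1`: 13000 nM

In a functional assay on HT-29 cells (Homo sapiens) for inhibition, read by sulforhodamine B assay, with a stated time of 48 h (on this read-out lower numbers stand for stronger inhibition of growth and higher numbers for weaker inhibition of growth), compound 3 stands highest of the three at 13000 nM. Compound 4 `Cc1ccc(NC2=NCCO2)cc1C` differs from it by one change: methyl in place of hydrogen on an aromatic carbon. Among the measured compounds shown here, no measured step makes this same change, so the evidence is indirect. The closest steps are an 8.7-fold higher number from compound 1 to compound 3 (0.94 log units; beyond the scatter) and a 10-fold higher number from compound 2 to compound 3 (1.00 log units; beyond the scatter), both beyond the scatter, whereas a 1.2-fold lower number from compound 1 to compound 2 (0.06 log units; within the scatter) lies within it. Compound 3 therefore sits above the other two, and a modest move towards their numbers is expected, smaller than those two steps. The estimated value for compound 4 is 5000 nM, with an expected range of 1800 nM to 14000 nM. The expected change is a 2.6-fold lower number from compound 3 to compound 4 (0.41 log units; beyond the scatter).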

Compound 4, concentration for 50% growth inhibition: 2700 nM
The estimate for compound 4 lay 1.9-fold (0.27 log units) above the measured number, and the stated range covers the measured number.
By their numbers in this assay, from the lowest: compounds 2, 1 and 4 (each within the scatter of the next, the first and the last beyond it); then compound 3.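

In this assay, methyl in place of hydrogen on the aromatic carbon ortho to a methyl group gives a 4.8-fold lower number from compound 3 to compound 4 (0.68 log units; beyond the scatter), a step beyond the scatter. Among the compounds shown here, compound 1, compound 2 and compound 3 differ only in one other group, so this is the first sign that the number also responds to a change at this position. Nothing available bears on the reason for this step.

On these data alone, whether an ethyl, a methoxy or an amine here would shift the number likewise remains open. So does whether the added methyl has the same effect alongside iodo or tert-butyl.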